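Methyl for Fluoro on the Phenoxy Ring of Compound 3

The source may hold more compounds than are shown below. What is called first, only, known or untested is meant among the compounds shown, and "the series" means these compounds.

Compound 1 `Cc1nn(C)c(Oc2ccc(F)cc2)c1/C=N\OCc1c(Cl)c(-c2ccc(F)cc2)nn1C`: 8020 nM
Compound 2 `COc1ccc(Oc2c(/C=N\OCc3c(Cl)c(-c4ccc(F)cc4)nn3C)c(C)nn2C)cc1`: 1180 nM
Compound 3 `Cc1nn(C)c(Oc2ccc(F)cc2)c1/C=N\OCc1c(Cl)c(-c2ccc(Cl)cc2)nn1C`: 7250 nM

In a functional assay on HCT-116 cells (Homo sapiens) for antiproliferative activity, read by MTT assay, with a stated time of 72 h (a higher number here means a weaker inhibitor, a lower number a stronger inhibitor), compound 3 gives the second highest of the three numbers. The step of a 1.1-fold lower number from compound 1 to compound 3 (0.04 log units; within the scatter) lies within the scatter, whereas the step of a 6.8-fold lower number from compound 1 to compound 2 (0.83 log units; beyond the scatter) was a modest shift beyond it. Compound 4 `Cc1ccc(Oc2c(/C=N\OCc3c(Cl)c(-c4ccc(Cl)cc4)nn3C)c(C)nn2C)cc1` differs from compound 3 by methyl in place of fluoro on an aromatic carbon. Among the measured compounds shown here, only the step from compound 1 to compound 2 touches this position, and it concerned a different entering group, so it bears on the change loosely. A smaller shift in the same direction is therefore expected, with wide uncertainty. The estimated step is a 2.1-fold lower number from compound 3 to compound 4 (0.32 log units; beyond the scatter). Compound 4 is thus expected to give 3500 nM in this assay, within a range from 1200 nM to 9000 nM.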

Compound 4, half-maximal inhibitory concentration: 2850 nM
Compound 4: middle estimate off by 1.2-fold (0.09 log units), on the high side, and the stated range covers the measured number.
By their numbers in this assay, from the lowest: compound 2; then compound 4; then compounds 3 and 1 (each within the scatter of the next).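

Fluoro to methyl on the phenoxy ring, measured directly in this assay, gives a 2.5-fold lower number from compound 3 to compound 4 (0.41 log units; beyond the scatter), a step beyond the scatter. Among the compounds shown here, until now, the only change seen at this position was methoxy in place of fluoro, with a fluoro rather than a chloro on the other aromatic ring, so a second entering group now also gives a lower number than fluoro. Nothing available explains this shift.
The compounds shown leave open whether an amine, a carboxylic acid or a longer chain at this position would lower the number. They also leave open whether methyl gives a similar step on compound 1.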